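Fluoro for hydrogen on the fused aromatic ring

This account rests on a few compounds, and the source may have more. Where it says the series, first, only, none or still open, it means among the compounds named here.

Measured compounds in a functional assay on CHO cells for agonist activity at Melanocortin receptor 4 (Homo sapiens), read by a luciferase reporter, with a stated time of 4 h; a lower number here means that less compound is needed, a higher number that more compound is needed for the effect:
compound 1 `CC(C)N(C(=O)CN1C=CN(c2ccccc2)C(=O)[C@@H](Cc2n[nH]c3cc(F)ccc23)C1=O)c1ccccc1` gives 31600 nM; > 30000 nM (2 entries).
compound 2 `CC(C)N(C(=O)CN1C=CN(c2ccccc2)C(=O)[C@H](Cc2n[nH]c3cc(F)ccc23)C1=O)c1ccccc1` gives 1260 nM.
compound 3 `CC(C)N(C(=O)CN1C=CN(c2ccccc2)C(=O)C(Cc2n[nH]c3ccccc23)C1=O)c1ccccc1` gives 3240 nM.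

For compound 1 part of the record is a limit of the assay rather than a number. Compounds 1 and 2 differ only in the drawn configuration, and compound 2 gives the lower number of the pair. Compound 3, drawn without configuration, stands highest of the two numbers; the nearest is compound 2, a gap beyond the scatter.

Compound 4 `CC(C)N(C(=O)CN1C=CN(c2ccccc2)C(=O)C(Cc2n[nH]c3cc(F)ccc23)C1=O)c1ccccc1` is not yet measured. From compound 3 the change is fluoro in place of hydrogen on an aromatic carbon. Compound 4 thus carries the same substitution as compounds 1 and 2 but, like compound 3, without drawn configuration. A modest downward step in this assay is expected, placing compound 4 between the values of compound 2 and compound 3, the step of a 1.3-fold lower number from compound 3 to compound 4 (0.11 log units; within the scatter) being expected to lie near the edge of the scatter. Compound 4 is estimated at 2500 nM, within 1000 nM to 6000 nM.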

Compound 4, half-maximal effective concentration: 537 nM
Beside the measured number, compound 4's estimate is 4.7-fold (0.67 log units) above it; the measured number lies below the stated range.
By their numbers in this assay, from the lowest: compound 4; then compound 2; then compound 3.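

In this assay, fluoro in place of hydrogen on the aromatic carbon meta to a fused ring and para to a fused ring gives a 6.0-fold lower number from compound 3 to compound 4 (0.78 log units; beyond the scatter), the first step read at this position, so this carbon responds to a single added heavy atom. Both compounds of that step are drawn without configuration. Against the fluoro compound with a drawn configuration, the comparison gives a 2.3-fold lower number from compound 2 to compound 4 (0.37 log units; beyond the scatter), with the lower number on the undefined form, and this step can be read only with a caution about the drawing: the fact that one of compounds 2 and 4 is drawn with a defined configuration and the other without, at the place where they differ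

On these data alone, the stereochemical make-up of compound 3 and compound 4 remains open, and with it how much of the step belongs to fluoro alone. Also open, as far as these compounds go, is how chloro, methoxy or a nitrile would behave on the same aromatic carbon.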